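The compounds below may be only part of what the source reports. "The series", "measured", "known", "first", "only" and "open" are said of these compounds alone.

Working notes on the series sharing the core of compound 1 `COc1cccc(CNc2ncnc3c2ncn3[C@@H]2O[C@H](CO)[C@@H](O)[C@H]2O)c1`. In a functional assay on B16 cells (Mus musculus) for antiproliferative activity, with a stated time of 72 h (on this read-out lower numbers stand for stronger inhibition and higher numbers for weaker inhibition), compound 1 gives only a limit, > 166000 nM, and not a number. That limit is the anchor of what is known here: the limit of > 166000 nM in this assay, at which 1 of the 2 values shown sits. Compound 2 `COc1cc(CNc2ncnc3c2ncn3[C@@H]2O[C@H](CO)[C@@H](O)[C@H]2O)cc(OC)c1` has no number in this assay; for compound 2 the result stands as "not determined" (no result reported), so compound 2 has no measured place on the scale. Within the data shown here, the only value of the pair is the limit of compound 1.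

Compound 3 `Cc1cccc(CNc2ncnc3c2ncn3[C@@H]2O[C@H](CO)[C@@H](O)[C@H]2O)c1O` differs from compound 2 by 2-hydroxy-3-methylphenyl in place of 3,5-dimethoxyphenyl on a saturated chain carbon bound to a nitrogen on an aromatic ring. No measured step is shown for this assay, so the size of the change from compound 2 to compound 3 cannot be read from numbers; no step beyond the scatter in either direction is expected on present evidence. Among the measured compounds shown here, with the single known value of the pair sitting at the limit, compound 3 is estimated at 150000 nM, with a range from 30000 nM to 600000 nM, and a limit rather than a number is expected as the likely report.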

Compound 3, half-maximal inhibitory concentration: > 166000 nM
Compound 3 was reported as a limit; the forecaster's own chance of this, stated with the estimate: 70%; middle value at least 1.1-fold (0.04 log units) away from the limit.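

Compound 1 and compound 3 are both reported only as a limit and not as a number, so no step between them can be read in this assay: the limit of > 166000 nM in this assay, at which 2 of the 3 values shown sit.

The compounds shown leave open how far compound 1 and compound 3 lie past that limit, and whether any group on the shared core gives a numerical value.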